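This account rests on a few compounds, and the source may have more. Where it says the series, first, only, none or still open, it means among the compounds named here.

Compound 1 `O=C(Cc1cccnc1)c1cc2cc(F)ccc2[nH]1`: 36000 nM
Compound 2 `O=C(Cc1cccnc1)c1cc2cc(Cl)ccc2[nH]1`: 24600 nM

Within the data shown here, in an assay on isolated protein for inhibition of Indoleamine 2,3-dioxygenase 1 (Homo sapiens), read by spectrophotometry (on this read-out higher numbers stand for weaker inhibition and lower numbers for stronger inhibition), compound 2 gives 24600 nM, and compound 1 gives 36000 nM; the only step between them, a 1.5-fold lower number from compound 1 to compound 2 (0.17 log units; within the scatter), lies within the scatter, so neither can be ranked above the other. Compound 3 `O=C(Cc1cccnc1)c1cc2cc(OC(F)(F)F)ccc2[nH]1` has not been measured. It differs from compound 2 by trifluoromethoxy in place of chloro on an aromatic carbon. Among the measured compounds shown here, the single step that bears on this exchange was small, so no shift beyond the scatter is expected in this assay. For compound 3 the expected step is a 1.2-fold lower number from compound 2 to compound 3 (0.09 log units; within the scatter). For compound 3 the estimate is 20000 nM, between 8000 nM and 60000 nM.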

Compound 3, half-maximal inhibitory concentration: 13100 nM
For compound 3 the middle estimate is 1.5-fold (0.18 log units) above the measured one; the range from low to high includes it.
By their numbers in this assay, from the lowest: compounds 3, 2 and 1 (each within the scatter of the next, the first and the last beyond it).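

In this assay the step of a 1.9-fold lower number from compound 2 to compound 3 (0.27 log units; within the scatter) stays within the scatter, whereas the step of a 2.7-fold lower number from compound 1 to compound 3 (0.44 log units; beyond the scatter) passes beyond it, modestly, giving the first separation among these compounds. This position therefore accepts trifluoromethoxy in place of either halogen without any loss, and with fluoro as the comparison the number falls. Nothing available explains this difference.

Going by these compounds, all three groups at this position contain halogen atoms, so it remains open how an amine, a carboxylic acid or a longer alkoxy chain would behave there.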